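Urea series: removing one trifluoromethyl from compound 3

The source may hold more compounds than are shown below. What is called first, only, known or untested is meant among the compounds shown, and "the series" means these compounds.

Compound 3 `COc1cc(Cl)cc(-c2nn(-c3cccc(NC(=O)Nc4cc(C(F)(F)F)cc(C(F)(F)F)c4)c3)cc2-c2ccncc2)c1` gives -15.6% in a functional assay on NCI-H522 cells (Homo sapiens) for inhibition, read by sulforhodamine B assay, with a stated time of 48 h, tested at 10 uM; on this read-out higher numbers stand for a weaker effect at the one concentration tested and lower numbers for a stronger effect; of the three numbers it is the second highest, with compound 1 `O=C(Nc1cccc(-n2cc(-c3ccncc3)c(-c3cc(O)cc(Cl)c3)n2)c1)Nc1ccc(Cl)c(C(F)(F)F)c1` at -16% nearest and compound 2 `COc1cc(Cl)cc(-c2nn(-c3cccc(NC(=O)Nc4ccc(Cl)c(C(F)(F)F)c4)c3)cc2-c2ccncc2)c1` at -10.4% furthest, both within the scatter. Compound 4 `COc1cc(Cl)cc(-c2nn(-c3cccc(NC(=O)Nc4cccc(C(F)(F)F)c4)c3)cc2-c2ccncc2)c1` differs from compound 3 by hydrogen in place of trifluoromethyl on an aromatic carbon. Among the compounds with values here, the only measured single-site step, a number 5.6 percentage points higher from compound 1 to compound 2 (within the scatter), touches a different part of the molecule and stays within the scatter, so nothing measured bears directly on loss of a trifluoromethyl. All three values sit close together near zero effect, and no step beyond the scatter is expected from compound 3 to compound 4 in this assay, giving an expected a number 3.6 percentage points higher from compound 3 to compound 4 (within the scatter). Compound 4 is estimated at -12%, within -26% to 2%.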

Compound 4, a percentage reported as activity, at one concentration (the size of the read-out at that concentration, not a potency): -18.6%
Compound 4: middle estimate off by 6.6 percentage points, on the high side; low and high end bracket the measured number.
By their numbers in this assay, from the lowest: compounds 4, 1, 3 and 2 (each within the scatter of the next).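

In this assay, hydrogen in place of trifluoromethyl on this aromatic ring gives a number 3 percentage points lower from compound 3 to compound 4 (within the scatter), and hydrogen in place of chloro gives a number 8.2 percentage points lower from compound 2 to compound 4 (within the scatter). The second trifluoromethyl and the chloro are therefore not needed to keep the read-out within the scatter of the other compounds at the one concentration tested. Nothing available explains why both steps remain this small.

As far as these compounds go, it remains open whether an amine or a carboxylic acid on this aromatic carbon would move the read-out beyond the scatter. From the compounds shown here alone, the effect of hydrogen in place of the remaining trifluoromethyl also remains open.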